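Cyclopropyl for Difluoromethyl on an Aryl Ether Chain

A few compounds are considered here, and "the series" means these few. Any claim that something is new, unique, unknown or untested is made for them only; others in the source may bear on it.

Compound 1, `O=C(O)Cn1nc(Cc2nc3cc(Cl)c(OCC(F)F)cc3[nH]2)c2ccccc2c1=O`, was tested in an ADME assay on microsomes from liver (Mus musculus) for metabolic stability; on this read-out higher numbers stand for fast clearance and lower numbers for slow clearance. In this assay compound 1 returned only a limit, < 56.7 mL/min/kg, not a number. Two companions were run alongside it. Compound 2, `CC(C(=O)O)c1nn(Cc2cn3cc(OCC4CC4)c(C(F)(F)F)cc3n2)c2ccccc2c1=O`, likewise gave only a limit in this assay, < 60 mL/min/kg. Compound 3, `CC(C)(C(=O)O)c1nn(Cc2cn3cc(OCC4CC4)c(Cl)cc3n2)c2ccccc2c1=O`, also stopped at a limit in this assay, < 63.4 mL/min/kg. So each of the three known values is a limit: the limit of < 56.7 mL/min/kg in this assay, at which 1 of the 3 values shown sits, the limit of < 60 mL/min/kg in this assay, at which 1 of the 3 values shown sits, and (the limit of < 63.4 mL/min/kg in this assay, at which 1 of the 3 values shown sits). Within the data shown here, no step between measured compounds can be computed from such readings.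

Compound 4, `O=C(O)Cn1nc(Cc2nc3cc(Cl)c(OCC4CC4)cc3[nH]2)c2ccccc2c1=O`, has not yet been measured. It differs from compound 1 in one place: cyclopropyl in place of difluoromethyl on a saturated chain carbon bound to an oxygen on an aromatic ring. Compounds 2 and 3 also carry a cyclopropylmethoxy group, and both sit at a limit in this assay. The step from compound 1 to compound 4 is therefore expected to be none beyond the scatter, and the expected step is a step that the limit leaves unreadable from compound 1 to compound 4. For compound 4 the estimated clearance in this assay is 30 mL/min/kg, expected between 10 mL/min/kg and 60 mL/min/kg, most likely again reported only as a limit.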

Compound 4, clearance: 147 mL/min/kg
Estimate against measurement, compound 4: 4.9-fold (0.69 log units) below; the whole stated range lies below it.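

In this assay, among these compounds, the change gives the first readable step at this position, an at least 2.5-fold higher number from compound 1 to compound 4 (0.41 log units; beyond the scatter), so cyclopropyl in place of difluoromethyl on this ether chain is not neutral on the core of compound 1. Among the compounds shown here, until now every reading had been a limit, and no step could be taken at this place or anywhere else among the compounds. Compound 1 itself remains at a limit, so the step sets only a minimum for the change and its full size stays unknown: the limit of < 56.7 mL/min/kg in this assay, at which 1 of the 4 values shown sits.

The compounds shown leave open whether the higher number goes with the three-membered ring or with the loss of the two fluorine atoms, a question that an open propyl or a trifluoroethyl chain at this place would help to separate. They also leave open whether the same swap would give a similar step on the cores of compound 2 and compound 3.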